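A few compounds are considered here, and "the series" means these few. Any claim that something is new, unique, unknown or untested is made for them only; others in the source may bear on it.

Measured so far:
- compound 1 `CCOc1cc(/C=C2\SC(=O)NC2=O)ccc1OCN1C(=O)c2ccccc2C1=O`: 29300 nM
- compound 2 `O=C1NC(=O)/C(=C/c2cccc(OCN3C(=O)c4ccccc4C3=O)c2)S1`: > 100000 nM

In an assay on isolated protein for inhibition of Alpha glucosidase (Homo sapiens), read by spectrophotometry, with stated times of 15 min and 30 min (a lower number here means a stronger inhibitor, a higher number a weaker inhibitor), compound 1 gives 29300 nM. For compound 2 this assay returns only > 100000 nM, which is a limit of the assay and not a number; it is the limit of > 100000 nM in this assay, at which 1 of the 2 values shown sits. Among the measured compounds shown here, compound 2 therefore has no fixed position on the scale, only a bound, and no measured step from it to any other compound is available.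

Compound 3 `O=C1NC(=S)S/C1=C\c1cccc(OCN2C(=O)c3ccccc3C2=O)c1` is not yet measured. It differs from compound 2 by a group of 8 heavy atoms (4 carbon, 1 nitrogen, 1 oxygen, 2 sulfur; one five-membered non-aromatic ring with 2 hetero atoms) in place of a group of 8 heavy atoms (4 carbon, 1 nitrogen, 2 oxygen, 1 sulfur; one five-membered non-aromatic ring with 2 hetero atoms), on an aromatic carbon, one sulfur entering where one oxygen leaves, with the rest of the structure kept. For the measured compounds named here, no measured step covers this exchange, so the direction of change in this assay can only be expected, not read from data. The expectation is for a modest gain in inhibition, of about an at least 1.6-fold lower number from compound 2 to compound 3 (0.22 log units; that floor lies within the scatter), though a step within the scatter or a second limit is also possible. Compound 3 is estimated at 60000 nM, with a range of 15000 nM to 200000 nM.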

Compound 3, half-maximal inhibitory concentration: 34000 nM
Compound 3: middle estimate off by 1.8-fold (0.25 log units), on the high side; measured number inside the range.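

In this assay, among the compounds shown here, exchanging one oxygen for one sulfur in the five-membered non-aromatic ring, on an aromatic carbon meta to a large group, gives an at least 2.9-fold lower number from compound 2 to compound 3 (0.46 log units; beyond the scatter), the only step that can be read so far. The leaving and entering groups have the same counts of hydrogen-bond donors, hydrogen-bond acceptors and double bonds outside aromatic rings, so these counts do not separate them, yet the exchange still moves the read-out. Compound 2 stands at a limit of the assay and not at a number, so the step has a floor but no measured size: the limit of > 100000 nM in this assay, at which 1 of the 3 values shown sits.

On these data alone, the true size of the step remains open, as does whether the same exchange carries over to the core of compound 1. Also open, as far as these compounds go, is how a carboxylic acid in place of the five-membered non-aromatic ring would read in this assay.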